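Swapping imidazolyl for triazolyl on a hydrazone scaffold

The source may hold more compounds than are shown below. What is called first, only, known or untested is meant among the compounds shown, and "the series" means these compounds.

Compound 1 `C(=N/Nc1nc(-c2ccccc2)cs1)\c1ccc(-n2ccnc2)cc1` gives 21.8% in an ADME assay on THP-1 cells (Homo sapiens) for cytotoxicity, read by MTT assay, tested at 50 ug/mL (on this read-out lower numbers stand for less inhibition and higher numbers for more inhibition at the one concentration tested (going by the name of the read-out)), the lowest of the three numbers measured. Compound 2 `Cc1ccc(-c2csc(N/N=C/c3ccc(-n4ccnc4)cc3)n2)cc1` gives 36%, and compound 3 `COc1ccc(-c2csc(N/N=C/c3ccc(-n4ccnc4)cc3)n2)cc1` gives 26.8%. The step of a number 14.2 percentage points higher from compound 1 to compound 2 (beyond the scatter) exceeds the scatter, whereas a number 5 percentage points higher from compound 1 to compound 3 (within the scatter) and a number 9.2 percentage points lower from compound 2 to compound 3 (within the scatter) do not. Compound 4 `C(=N/Nc1nc(-c2ccccc2)cs1)\c1ccc(-n2cncn2)cc1` differs from compound 1 in one place: 1H-1,2,4-triazol-1-yl in place of 1H-imidazol-1-yl on an aromatic carbon. Both measured steps alter a group elsewhere in the molecule, so neither bears directly on this exchange; the small size of a number 5 percentage points higher from compound 1 to compound 3 (within the scatter) only hints that one small group replacing another need not move the read-out much. No change beyond the scatter is therefore expected, and the estimated step of a number 1.2 percentage points higher from compound 1 to compound 4 (within the scatter) is small. Compound 4 is expected to give 23%, within a range from 12% to 36%.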

Compound 4, a percentage reported as inhibition, at one concentration (the size of the read-out at that concentration, not a potency): 28.4%
Compound 4: middle estimate off by 5.4 percentage points, on the low side, and the stated range covers the measured number.
By their numbers in this assay, from the lowest: compounds 1, 3, 4 and 2 (each within the scatter of the next, the first and the last beyond it).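

In this assay, the only change shown at this position, on the aromatic carbon para to a large group, gives a number 6.6 percentage points higher from compound 1 to compound 4 (within the scatter). Going from 1H-imidazol-1-yl to 1H-1,2,4-triazol-1-yl, with a third nitrogen in the ring, therefore leaves the read-out within the usual scatter. No measurement here offers an explanation for this result.

As far as these compounds go, whether an open-chain group at this position, such as an amine or a carboxylic acid, would behave the same remains open. So does whether this exchange would give a similar result on compound 2 or compound 3.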